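A Methoxy Group Added to Compound 2

A few compounds are considered here, and "the series" means these few. Any claim that something is new, unique, unknown or untested is made for them only; others in the source may bear on it.

Of the compounds shown here, three have been tested so far in a functional assay on HCT-116 cells (Homo sapiens) for antiproliferative activity, read by sulforhodamine B assay, with a stated time of 48 h; a lower number here means a stronger inhibitor of growth, a higher number a weaker inhibitor of growth. Compound 2 (`O=C(/C=C/c1cccc(S(=O)(=O)c2ccc3ccccc3n2)c1)NO`) gives 80 nM, the lowest of the three numbers and therefore the strongest growth inhibition. Compound 1 (`COc1ccc(S(=O)(=O)c2ccc3ccc(/C=C/C(=O)NO)cc3n2)cc1`) gives 240 nM, and compound 3 (`O=C(/C=C/c1ccc(S(=O)(=O)c2ccc3ccccc3n2)cc1)NO`) gives 310 nM. These two values lie within the usual scatter of each other, while compound 2 stands clearly apart from both, beyond that scatter.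

The next compound to be tested is compound 4 (`COc1ccc2nc(S(=O)(=O)c3cccc(/C=C/C(=O)NO)c3)ccc2c1`). It is compound 2 with methoxy in place of hydrogen on an aromatic carbon. The new group sits on a six-membered aromatic ring of carbon only, part of a fused system of two rings.

Among the measured compounds shown here, no two measured compounds differ in just one place, so the data offer no direct measure of what this change does in this assay. The expectation therefore has to be a cautious one. Compound 2 already holds the lowest number, at 80 nM, so a modest rise seems more likely than a further fall, though a step within the scatter would be no surprise. The expected change is a 1.5-fold higher number from compound 2 to compound 4 (0.18 log units; within the scatter). For compound 4 the estimated value is 120 nM, with an expected range from 45 nM to 320 nM.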

Compound 4, concentration for 50% growth inhibition: 240 nM
Compound 4: middle estimate off by 2.0-fold (0.30 log units), on the low side; low and high end bracket the measured number.
By their numbers in this assay, from the lowest: compound 2; then compounds 1, 4 and 3 (each within the scatter of the next).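

Compound 2 and compound 4 form the only pair shown that differs in one place, so this assay now gives a direct reading of a single change. Methoxy in place of hydrogen brings a 3.0-fold higher number from compound 2 to compound 4 (0.48 log units; beyond the scatter) on this six-membered aromatic ring of carbon only, part of the fused system of two rings. Among the compounds shown here, the step lies beyond the scatter, so at this position, on the core of compound 2, the added group costs growth inhibition rather than leaving it unchanged, a cost that the earlier compounds, with no such pair among them, could not show. Nothing at hand explains why the number rises.

The compounds shown leave open whether this loss belongs to methoxy itself or would follow any group on this carbon, and a fluorine, a hydroxyl or an amine in the same place would help to tell these apart. Also open, as far as these compounds go, is whether methoxy on another carbon of the same ring, or the same change made on compound 3, would give a step of similar size.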